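A few compounds are considered here, and "the series" means these few. Any claim that something is new, unique, unknown or untested is made for them only; others in the source may bear on it.

Measured so far in a functional assay on HL-60 cells (Homo sapiens) for antiproliferative activity, read by XTT assay, with a stated time of 72 h (on this read-out lower numbers stand for stronger inhibition and higher numbers for weaker inhibition), and listed here
- compound 1 `CSc1ncnc2c1c(-c1ccsc1)cn2[C@@H]1O[C@H](CO)[C@@H](O)[C@H]1O` gives 4590 nM
- compound 2 `CN(C)c1ncnc2c1c(-c1ccsc1)cn2[C@@H]1O[C@H](CO)[C@@H](O)[C@H]1O` gives 1920 nM
- compound 3 `Cc1ncnc2c1c(-c1ccoc1)cn2[C@@H]1O[C@H](CO)[C@@H](O)[C@H]1O` gives > 15000 nM as a limit

Compound 3 gives no number, only a limit, as the limit of > 15000 nM in this assay, at which 1 of the 3 values shown sits, records. Compound 4 `Cc1ncnc2c1c(-c1ccsc1)cn2[C@@H]1O[C@H](CO)[C@@H](O)[C@H]1O` carries thiophen-3-yl in place of furan-3-yl on an aromatic carbon and keeps everything else from compound 3.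

Within the data shown here, no measured pair differs by this swap alone. Among the measured compounds shown here, the one measured step, a 2.4-fold lower number from compound 1 to compound 2 (0.38 log units; beyond the scatter), is modest and concerns dimethylamino in place of methylsulfanyl, so it sets no size for the swap. For the measured compounds named here, it shows only that thiophen-3-yl compounds can give numbers, as compound 1 does at 4590 nM and compound 2 at 1920 nM in this assay, though both also differ from compound 4 at the methyl group.

A move towards a lower number is therefore expected, of loosely known size. The expected step is an at least 2.5-fold lower number from compound 3 to compound 4 (0.39 log units; beyond the scatter), an estimate measured from a limit. For compound 4 the estimated value is 6000 nM, with an expected range of 2000 nM to 15000 nM in this assay.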

Compound 4, half-maximal inhibitory concentration: 350 nM
Estimate against measurement, compound 4: 17-fold (1.23 log units) above; the whole stated range lies above it.
By their numbers in this assay, from the lowest: compound 4; then compound 2; then compound 1. At a limit, above all of these: compound 3.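

In this assay compound 3 stands as a limit and not a number: the limit of > 15000 nM in this assay, at which 1 of the 4 values shown sits. Even so, thiophen-3-yl in place of furan-3-yl on this aromatic carbon gives an at least 42-fold lower number from compound 3 to compound 4 (1.63 log units; beyond the scatter) and this single swap takes the series from a limit to the lowest number shown, a size that no earlier step could indicate. With thiophen-3-yl kept, the group on the other aromatic carbon also matters: methyl gives a 5.5-fold lower number from compound 2 to compound 4 (0.74 log units; beyond the scatter) against dimethylamino and a 13-fold lower number from compound 1 to compound 4 (1.12 log units; beyond the scatter) against methylsulfanyl.

As far as these compounds go, it remains open whether the same swap gives a step of similar size with dimethylamino or methylsulfanyl in place of methyl. Also open, from the compounds shown here alone, is how phenyl in place of thiophen-3-yl, or ethyl or methoxy in place of methyl, would read.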